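Chloro for iodo on the aryl amide of compound 1

The compounds below may be only part of what the source reports. "The series", "measured", "known", "first", "only" and "open" are said of these compounds alone.

The shared core carries an amide-linked aryl ring, and the three measured compounds differ only in that ring. In an assay on membranes from Cerebral cortex for displacement of a labelled ligand from Neuronal acetylcholine receptor; alpha4/beta2 (Rattus norvegicus) (on this read-out higher numbers stand for weaker inhibition and lower numbers for stronger inhibition), compound 1 `O=C(Nc1ccc(I)cc1)c1cncc(N2CC3CC(C2)N3)c1` gives 0.366 nM, which places it second highest of the three numbers. Compound 2 `COc1ccc(NC(=O)c2cncc(N3CC4CC(C3)N4)c2)cc1OC` gives 0.828 nM in this assay, the nearest neighbour of compound 1. Compound 3 `O=C(Nc1ccc(F)cc1F)c1cncc(N2CC3CC(C2)N3)c1` gives 0.051 nM, and the change recorded between the two is a 7.2-fold lower number from compound 1 to compound 3 (0.86 log units; beyond the scatter).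

Compound 4 `O=C(Nc1ccc(Cl)cc1)c1cncc(N2CC3CC(C2)N3)c1` has not yet been measured in this assay. Its difference from compound 1 is chloro in place of iodo on an aromatic carbon, para to a large group. Among the measured compounds shown here, no measured step exchanges one halogen for another at this position. The step from compound 1 to compound 3 shows that the aryl substituents can move the number beyond the scatter, but it changes the pattern of substitution as well as the halogen, so it bears only loosely on the present change. On this basis the step is expected to be small, a 1.2-fold lower number from compound 1 to compound 4 (0.09 log units; within the scatter), with no firm direction. Compound 4 is therefore estimated at 0.3 nM, within a range of 0.1 nM to 0.9 nM.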

Compound 4, inhibition constant: 0.404 nM
The estimate for compound 4 lay 1.3-fold (0.13 log units) below the measured number; the range from low to high includes it.
By their numbers in this assay, from the lowest: compound 3; then compounds 1 and 4 (each within the scatter of the next); then compound 2.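

In this assay, among the compounds shown here, the exchange of iodo for chloro on an aromatic carbon, para to a large group, gives a 1.1-fold higher number from compound 1 to compound 4 (0.04 log units; within the scatter), and this is the first direct reading of one halogen against another at this position; within the scatter, the read-out does not separate 4-iodophenyl from 4-chlorophenyl. The other new step, a 7.9-fold higher number from compound 3 to compound 4 (0.90 log units; beyond the scatter), shows that the 4-chlorophenyl compound stands as far from the 2,4-difluorophenyl compound as the iodo compound does, so the gap to compound 3 does not depend on which of these two heavier halogens is present. No measurement is available here to explain why the two halogens read alike or why compound 3 stands apart.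

The compounds shown leave open whether the gap to compound 3 belongs to fluoro itself or to the pattern of substitution, a question that a single fluoro in place of the chloro of compound 4 would help to settle. They also leave open how far the number would move with a plain phenyl ring, or with a methyl, an amine or a carboxylic acid in place of the halogen.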